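The source may report more compounds than this note shows. Statements on the series, on what has been measured and on what is new or still open speak of the compounds shown alone.

Measured compounds:
- compound 1, `Cn1cnnc1SCC(=O)N/N=c1/scc(-c2ccc(Br)cc2)n1-c1ccccc1`: 58.3 ug/mL
- compound 2, `Cn1cnnc1SCC(=O)N/N=c1/scc(-c2ccc([N+](=O)[O-])cc2)n1-c1ccccc1`: 133 ug/mL
- compound 3, `Cc1ccc(-c2cs/c(=N/NC(=O)CSc3nncn3C)n2-c2ccccc2)cc1`: 130 ug/mL

All three compounds share a common core and differ only in the group carried on one aromatic carbon. In an ADME assay on NIH3T3 cells (Mus musculus) for cytotoxicity, read by MTT assay, with a stated time of 24 h (a lower number here means a stronger inhibitor, a higher number a weaker inhibitor), compound 3 stands second highest of the three numbers. Its nearest neighbour is compound 2, with a 1.0-fold lower number from compound 2 to compound 3 (0.01 log units; within the scatter); the furthest is compound 1, with a 2.2-fold higher number from compound 1 to compound 3 (0.35 log units; beyond the scatter).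

Compound 4, `Cn1cnnc1SCC(=O)N/N=c1/scc(-c2ccccc2)n1-c1ccccc1`, has not yet been measured. Its change from compound 3 is hydrogen in place of methyl on an aromatic carbon.

Among the measured compounds shown here, no measured step exchanges methyl for hydrogen, so no step bears directly on this change. The steps that touch the same aromatic carbon are a 2.3-fold higher number from compound 1 to compound 2 (0.36 log units; beyond the scatter), a 2.2-fold higher number from compound 1 to compound 3 (0.35 log units; beyond the scatter) and a 1.0-fold lower number from compound 2 to compound 3 (0.01 log units; within the scatter): two of them are modest and one stays within the scatter. Swapping one group for another at this position has therefore shifted the number only modestly at most, and with hydrogen entering there is nothing to point in either direction. The step in this assay from compound 3 to compound 4 is expected to be small, likely within the scatter, as a 1.2-fold lower number from compound 3 to compound 4 (0.07 log units; within the scatter). Compound 4 is accordingly estimated at 110 ug/mL, with a range from 55 ug/mL to 220 ug/mL.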

Compound 4, half-maximal inhibitory concentration: 217 ug/mL
The estimate for compound 4 lay 2.0-fold (0.30 log units) below the measured number; measured number inside the range.
By their numbers in this assay, from the lowest: compound 1; then compounds 3, 2 and 4 (each within the scatter of the next).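

In this assay, among the compounds shown here, compound 4 gives the first reading with no group at all on this aromatic carbon, so the other groups can now be set against a plain phenyl, with a 1.7-fold higher number from compound 3 to compound 4 (0.22 log units; within the scatter) and with a 1.6-fold higher number from compound 2 to compound 4 (0.21 log units; within the scatter) as the two steps that stay within the usual scatter: neither methyl nor nitro can be told apart from hydrogen here. Bromo alone stands clear of the plain phenyl, with a 3.7-fold higher number from compound 1 to compound 4 (0.57 log units; beyond the scatter) as the widest step seen at this carbon, though still a modest one, so compound 1 keeps the lowest number of the four while the other three cannot be separated from one another. Nothing among the data at hand accounts for what sets bromo apart.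

The compounds shown leave open whether this separation belongs to bromo alone or would also appear with chloro or iodo on the same carbon. They also leave open how an amine, a carboxylic acid or a longer chain at this place would read in this assay against the plain phenyl of compound 4.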